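This account rests on a few compounds, and the source may have more. Where it says the series, first, only, none or still open, it means among the compounds named here.

Of the compounds shown here, three built on one shared core have been tested in a functional assay on K562 cells (Homo sapiens) for cytotoxicity, read by MTT assay, with a stated time of 72 h; a higher number here means a weaker inhibitor of growth, a lower number a stronger inhibitor of growth. Compound 1 `C[Se]/C(=N\C(=O)c1cccs1)NC(=O)c1cccs1` gives 6070 nM, compound 2 `C[Se]/C(=N\C(=O)c1ccco1)NC(=O)c1ccco1` gives 8780 nM, and compound 3 `C[Se]/C(=N\C(=O)c1sccc1Cl)NC(=O)c1sccc1Cl` gives 4810 nM. The number for compound 2 is the highest of the three, yet its gaps to compound 1 and to compound 3 both lie within the scatter, so the three read as alike. Compound 4 `CS/C(=N\C(=O)c1ccco1)NC(=O)c1ccco1` has not yet been measured; it differs from compound 2 in one place: a group of 2 heavy atoms (1 carbon, 1 sulfur; no ring) in place of a group of 2 heavy atoms (1 carbon, 1 selenium; no ring), on a carbon with a double bond to nitrogen. For the measured compounds named here, no measured pair shows a change of this kind, so the size and direction of the step remain open. Compound 4 is expected to give 15000 nM (range 5000 nM to 50000 nM) in this assay, an estimated step of a 1.7-fold higher number from compound 2 to compound 4 (0.23 log units; within the scatter) toward a higher number, with wide uncertainty.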

Compound 4, concentration for 50% growth inhibition: 64800 nM
The estimate for compound 4 lay 4.3-fold (0.64 log units) below the measured number, and the stated range ends below it.
By their numbers in this assay, from the lowest: compounds 3, 1 and 2 (each within the scatter of the next); then compound 4.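

In this assay the methylsulfanyl group in place of the selenium-bearing group, on a carbon with a double bond to nitrogen, gives a 7.4-fold higher number from compound 2 to compound 4 (0.87 log units; beyond the scatter) and this step lies beyond the scatter. For the compounds shown here, the earlier compounds all carry the selenium-bearing group, so only this pair shows that a change at this position can move the number. Nothing measured here accounts for the step.

The compounds shown leave open whether the same exchange gives a like step in compound 1 or compound 3. Going by these compounds, how an amine or a longer chain such as ethylsulfanyl would read at this place also stays open.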